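Solubility across the side-chain variants of the shared core

This account rests on a few compounds, and the source may have more. Where it says the series, first, only, none or still open, it means among the compounds named here.

Measured so far:
compound 1 `CC(C)C(c1ccc(-c2ccc3cccc(F)c3c2)[nH]c1=O)N1CCCCC1=O` — 23100 nM
compound 2 `CC(C)C(/C=C1\CCNC1=O)c1ccc(-c2ccc3cccc(F)c3c2)[nH]c1=O` — 20700 nM
compound 3 `CC(C)C(Nc1nnc[nH]1)c1ccc(-c2ccc3cccc(F)c3c2)[nH]c1=O` — 17200 nM

In a physicochemical assay for solubility, in phosphate buffer, measured as kinetic solubility (a higher number here means a more soluble compound, a lower number a less soluble compound), the three compounds give numbers that all lie within the scatter of one another, so compound 1 stands apart from none of them. The step of a 1.1-fold lower number from compound 1 to compound 2 (0.05 log units; within the scatter) and the step of a 1.3-fold lower number from compound 1 to compound 3 (0.13 log units; within the scatter) both change the same position as the one now varied, and both stay within the scatter; so does a 1.2-fold lower number from compound 2 to compound 3 (0.08 log units; within the scatter).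

Compound 4 `CC(C)C(Cc1noc(=O)[nH]1)c1ccc(-c2ccc3cccc(F)c3c2)[nH]c1=O` differs from compound 1 by a group of 7 heavy atoms (3 carbon, 2 nitrogen, 2 oxygen; one five-membered aromatic ring with 3 hetero atoms) in place of a group of 7 heavy atoms (5 carbon, 1 nitrogen, 1 oxygen; one six-membered non-aromatic ring with 1 hetero atom), on a saturated chain carbon bound to an aromatic carbon and a saturated chain carbon. Within the data shown here, since every exchange at this position so far has left this assay unchanged beyond the scatter, compound 4 is expected to show a 1.2-fold lower number from compound 1 to compound 4 (0.06 log units; within the scatter), i.e. no step beyond the scatter. Compound 4 is estimated at 20000 nM, within 10000 nM to 40000 nM.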

Compound 4, solubility: 30400 nM
Estimate against measurement, compound 4: 1.5-fold (0.18 log units) below; measured number inside the range.
By their numbers in this assay, from the lowest: compounds 3, 2, 1 and 4 (each within the scatter of the next).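

Working notes: a five-membered aromatic ring with 3 hetero atoms, holding 1 hydrogen-bond donor and 3 hydrogen-bond acceptors, enters at this position in this assay and gives a 1.3-fold higher number from compound 1 to compound 4 (0.12 log units; within the scatter) as well as a 1.5-fold higher number from compound 2 to compound 4 (0.17 log units; within the scatter) and a 1.8-fold higher number from compound 3 to compound 4 (0.25 log units; within the scatter) in the same series. The largest of these steps stays within the scatter, so all four side chains at this position remain indistinguishable in this read-out. No supporting data bear on this result.

Still open, from the compounds shown here alone, is whether an amine or a carboxylic acid at this position would also stay within the scatter. A longer chain carrying the same ring is equally unresolved.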